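A few compounds are considered here, and "the series" means these few. Any claim that something is new, unique, unknown or untested is made for them only; others in the source may bear on it.

Measured so far in an ADME assay on A549 cells (Homo sapiens) for cytotoxicity, read by MTT assay, with a stated time of 48 h; on this read-out lower numbers stand for stronger inhibition of growth and higher numbers for weaker inhibition of growth:
- Compound 1 `O=C(/C=C\c1ccc([N+](=O)[O-])cc1)N1N=C(c2ccncc2)OC1c1c[nH]c2ccccc12`: > 30 ug/mL, a limit.
- Compound 2 `O=C(/C=C\c1ccc(F)cc1)N1N=C(c2ccncc2)OC1c1c[nH]c2ccccc12`: > 30 ug/mL, a limit.

Compound 2 therefore has a limit and no number. Among the measured compounds shown here, the only evidence on this read-out so far is the limit of > 30 ug/mL in this assay, at which 2 of the 2 values shown sit. The next compound is compound 3 `O=C(/C=C\c1ccc(Cl)cc1Cl)N1N=C(c2ccncc2)OC1c1c[nH]c2ccccc12`, and the change is 2,4-dichlorophenyl in place of 4-fluorophenyl on a double-bonded chain carbon bound to a double-bonded chain carbon. For the measured compounds named here, one measured step bears on it, since it also swaps the aromatic group on that chain: a step that the two limits leave unreadable from compound 1 to compound 2. That step gives no size to carry over, and no direction either. The expectation therefore rests on a step that the two limits leave unreadable from compound 1 to compound 2 and stays close to the limit. The expected change in this assay is a number no higher from compound 2 to compound 3 (the limit leaves the size open), estimated as nothing beyond the usual scatter. For compound 3 the estimate is 30 ug/mL, with an expected range of 12 ug/mL to 60 ug/mL. A further limit is the likeliest report.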

Compound 3, concentration for 50% growth inhibition: > 30 ug/mL
Compound 3 gave a limit, no number; the forecaster's own chance of this, stated with the estimate: 75%; the middle value lies on the limit itself.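

Compound 1, compound 2 and compound 3 all give limits and no numbers in this assay, so no step among them can be read: the limit of > 30 ug/mL in this assay, at which 3 of the 3 values shown sit.

Left open is whether 4-nitrophenyl, 4-fluorophenyl and 2,4-dichlorophenyl differ at all on this read-out, and in which direction.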